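The source may report more compounds than this note shows. Statements on the series, on what has been measured and on what is new or still open speak of the compounds shown alone.

Measured so far in a functional assay on HeLa cells (Homo sapiens) for cytotoxicity, read by MTT assay, with a stated time of 48 h; on this read-out lower numbers stand for stronger inhibition and higher numbers for weaker inhibition:
- compound 1 `Cc1nc2c3ccccc3ccc2c2nc3c(ccc4ccccc43)c(-c3cccc([N+](=O)[O-])c3)c12` gives 50700 nM
- compound 2 `Cc1nc2c3ccccc3ccc2c2nc3c(ccc4ccccc43)c(-c3cc([N+](=O)[O-])ccc3N)c12` gives 5770 nM
- compound 3 `Cc1nc2c3ccccc3ccc2c2nc3c(ccc4ccccc43)c(-c3ccccc3N)c12` gives 16200 nM

Compound 3 stands second highest of the three numbers, between compound 2 and compound 1. Compound 4 `Cc1ccc(-c2c3ccc4ccccc4c3nc3c2c(C)nc2c4ccccc4ccc32)cc1` carries 4-methylphenyl in place of 2-aminophenyl on an aromatic carbon. Among the compounds with values here, two measured steps bear on it: a 2.8-fold higher number from compound 2 to compound 3 (0.45 log units; beyond the scatter), where a hydrogen-bond acceptor left the pendant ring, and an 8.8-fold lower number from compound 1 to compound 2 (0.94 log units; beyond the scatter), where a hydrogen-bond donor entered it. Both point the same way: stripping donors and acceptors from the pendant ring raises the number. The 4-methylphenyl of compound 4 carries neither, so a modest rise beyond the scatter is expected, a 2.5-fold higher number from compound 3 to compound 4 (0.39 log units; beyond the scatter). Compound 4 is therefore estimated at 40000 nM, with a range from 15000 nM to 100000 nM.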

Compound 4, half-maximal inhibitory concentration: 72200 nM
Beside the measured number, compound 4's estimate is 1.8-fold (0.26 log units) below it; low and high end bracket the measured number.
By their numbers in this assay, from the lowest: compound 2; then compound 3; then compounds 1 and 4 (each within the scatter of the next).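

Working from the 2-aminophenyl, a 4.5-fold higher number from compound 3 to compound 4 (0.65 log units; beyond the scatter) in this assay shows that the 4-methylphenyl on this aromatic carbon loses the lower number, and a 13-fold higher number from compound 2 to compound 4 (1.10 log units; beyond the scatter) is the widest gap in the series. With a 1.4-fold higher number from compound 1 to compound 4 (0.15 log units; within the scatter), 4-methylphenyl and 3-nitrophenyl cannot be told apart, so among these compounds only the amino-bearing rings of compound 2 and compound 3 give the lower numbers. No supporting data explain these gaps.

From the compounds shown here alone, whether a hydroxyl or a dimethylamino group on the ring would match the amino group remains open. Going by these compounds, the effect of 2-methylphenyl, which would separate group identity from ring placement, also remains open.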